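From trifluoromethyl to 3-fluorophenyl on compound 2

The source may hold more compounds than are shown below. What is called first, only, known or untested is meant among the compounds shown, and "the series" means these compounds.

Among the compounds with values here, in an ADME assay on the whole organism (Mus musculus, strain Swiss Webster) for pharmacokinetics, read by LC-MS, at a dose of 50 mg/kg by the oral route (on this read-out lower numbers stand for lower exposure and higher numbers for higher exposure at the dose given), compound 2 `O=C(Nc1ccc(F)c(-c2nc3ncc(C(F)(F)F)cc3[nH]2)c1)N1CCCC1` gives 1080 nM, the lower of the two numbers so far, while compound 1 `O=C(Nc1ccc(F)c(-c2nc3ncc(-c4ccc(F)cc4)cc3[nH]2)c1)N1CCCC1` gives 6270 nM. Compound 3 `O=C(Nc1ccc(F)c(-c2nc3ncc(-c4cccc(F)c4)cc3[nH]2)c1)N1CCCC1` carries 3-fluorophenyl in place of trifluoromethyl on an aromatic carbon. Within the data shown here, the only measured step bearing on this is a 5.8-fold lower number from compound 1 to compound 2 (0.76 log units; beyond the scatter), where trifluoromethyl took the place of 4-fluorophenyl. The new change runs the opposite way, so a rise of similar size is expected in this assay. No measurement separates 3-fluorophenyl from 4-fluorophenyl. The expected step is a 4.6-fold higher number from compound 2 to compound 3 (0.67 log units; beyond the scatter). For compound 3 the estimated value is 5000 nM, with a range of 2000 nM to 12000 nM.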

Compound 3, maximal plasma concentration: 7000 nM
Compound 3: the middle estimate sits 1.4-fold (0.15 log units) below what was measured; the measured number falls inside the stated range.
By their numbers in this assay, from the lowest: compound 2; then compounds 1 and 3 (each within the scatter of the next).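

In this assay, the second fluorophenyl group also stands clear of trifluoromethyl on this aromatic carbon, with a 6.5-fold higher number from compound 2 to compound 3 (0.81 log units; beyond the scatter). The fluorine's place on the phenyl ring makes no readable difference here, with a 1.1-fold higher number from compound 1 to compound 3 (0.05 log units; within the scatter). No measured evidence accounts for the gap between the fluorophenyl groups and trifluoromethyl. Open, as far as these compounds go, is whether the fluorine matters at all, which plain phenyl would test. Also open, from the compounds shown here alone, is whether a ring is needed, which a longer alkyl chain or an amine on this carbon would test.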